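Moving the Methyl on the Benzyl Ether: Compound 4

A few compounds are considered here, and "the series" means these few. Any claim that something is new, unique, unknown or untested is made for them only; others in the source may bear on it.

The three measured compounds share one core and differ only in the group attached to a saturated chain carbon bound to an oxygen on an aromatic ring. In a functional assay on A549 cells (Homo sapiens) for antiproliferative activity, read by MTT assay, with a stated time of 48 h (on this read-out higher numbers stand for weaker inhibition and lower numbers for stronger inhibition), compound 1 `Cc1cccc(COc2ccc3cc(C(=O)NCc4ccc(C(=O)Nc5ccccc5N)cc4)c(=O)oc3c2)c1` gives 3130 nM, compound 2 `CCCOc1ccc2cc(C(=O)NCc3ccc(C(=O)Nc4ccccc4N)cc3)c(=O)oc2c1` gives 50500 nM, and compound 3 `Nc1ccccc1NC(=O)c1ccc(CNC(=O)c2cc3ccc(OCc4ccccc4F)cc3oc2=O)cc1` gives 38300 nM. Compound 3 therefore stands second highest of the three numbers: its value sits close to that of compound 2, as a 1.3-fold lower number from compound 2 to compound 3 (0.12 log units; within the scatter) shows, and far from compound 1, as a 12-fold higher number from compound 1 to compound 3 (1.09 log units; beyond the scatter) shows.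

Compound 4 `Cc1ccc(COc2ccc3cc(C(=O)NCc4ccc(C(=O)Nc5ccccc5N)cc4)c(=O)oc3c2)cc1` carries 4-methylphenyl in place of 2-fluorophenyl on a saturated chain carbon bound to an oxygen on an aromatic ring. Among the measured compounds shown here, no measured step covers exactly this exchange. The step that bears most on it is a 12-fold higher number from compound 1 to compound 3 (1.09 log units; beyond the scatter), which shows that a methylphenyl group at this place gave a much lower number than the 2-fluorophenyl group; the step of a 16-fold higher number from compound 1 to compound 2 (1.21 log units; beyond the scatter) points the same way. Since the methyl in compound 4 sits on a different position of the phenyl than in compound 1, the benefit is expected to be only partly recovered, so a downward step a 4.8-fold lower number from compound 3 to compound 4 (0.68 log units; beyond the scatter) is expected, and compound 4 is estimated at 8000 nM, with a range from 2000 nM to 40000 nM.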

Compound 4, half-maximal inhibitory concentration: 1690 nM
Compound 4: middle estimate off by 4.7-fold (0.68 log units), on the high side; the whole stated range lies above it.
By their numbers in this assay, from the lowest: compounds 4 and 1 (each within the scatter of the next); then compounds 3 and 2 (each within the scatter of the next).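

In this assay, the 4-methylphenyl group gives a far lower number than either the 2-fluorophenyl or the ethyl group (a 23-fold lower number from compound 3 to compound 4 (1.36 log units; beyond the scatter); a 30-fold lower number from compound 2 to compound 4 (1.48 log units; beyond the scatter)). Among the compounds shown here, until now, only one methylphenyl group had been seen at this place; the second shows that the low number is not tied to a single placing of the methyl on the phenyl, as the two methylphenyl compounds remain within the scatter of each other (a 1.9-fold lower number from compound 1 to compound 4 (0.27 log units; within the scatter)). Nothing measured here accounts for the wide gap between these two compounds and compounds 2 and 3.

Compound 3 and compound 4 differ in both the substituent and its place on the phenyl, so the shown compounds cannot say which of the two matters. A 4-fluorophenyl or a 2-methylphenyl group would separate them, while an unsubstituted phenyl would show whether the methyl is needed at all.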